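Amide variation on a pyrazole series for receptor modulation

The compounds below may be only part of what the source reports. "The series", "measured", "known", "first", "only" and "open" are said of these compounds alone.

Measured compounds:
- compound 1 `Cc1ccc(C(=O)Nc2cc(-c3ccccc3)nn2-c2ccccc2)cc1` gives 64 nM
- compound 2 `COc1cccc(-n2nc(-c3ccccc3)cc2NC(=O)c2ccccc2)c1` gives 570 nM
- compound 3 `N#Cc1cccc(C(=O)Nc2cc(-c3ccccc3)nn2-c2ccccc2Br)c1` gives 50 nM

In a functional assay on cells for positive allosteric modulation of metabotropic glutamate receptor 5 (Rattus norvegicus), read by calcium flux (on this read-out higher numbers stand for an effect only at larger amounts of compound and lower numbers for an effect already at smaller amounts), compound 1 and compound 3 sit within the scatter of one another, so nothing separates them. Compound 2 stands apart with a clearly higher number than compound 1, beyond the scatter. Within the data shown here, no pair among the three differs in one place only, so no single step can be read from the measured set.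

The next compound, compound 4 `O=C(Nc1cc(-c2ccccc2)nn1-c1ccccc1)C1=CCCCC1`, is unmeasured and differs from compound 1 in one place: cyclohex-1-en-1-yl in place of 4-methylphenyl on a carbonyl carbon. No comparable change occurs among the measured compounds, so the direction has to be guessed. Replacing the aromatic ring by a non-aromatic one at this position is expected to cost somewhat, and the step of a 2.3-fold higher number from compound 1 to compound 4 (0.37 log units; beyond the scatter) is estimated to lie modestly beyond the scatter, towards a higher number. For compound 4 the expected value is 150 nM, within a range of 50 nM to 500 nM.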

Compound 4, half-maximal effective concentration: 3300 nM
Compound 4: middle estimate off by 22-fold (1.34 log units), on the low side; the measured number lies above the stated range.
By their numbers in this assay, from the lowest: compounds 3 and 1 (each within the scatter of the next); then compound 2; then compound 4.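

In this assay, among these compounds, cyclohex-1-en-1-yl in place of 4-methylphenyl on the carbonyl carbon gives a 52-fold higher number from compound 1 to compound 4 (1.71 log units; beyond the scatter), the first step that can be read at a single place, and it shows that this position is far from indifferent to the ring it carries. The step removes the aromatic ring and the methyl group together, so it cannot say which of the two accounts for the change. Nothing at hand explains the size of the step.

From the compounds shown here alone, it remains open whether a fully saturated cyclohexyl, a morpholine ring or a longer chain such as n-butyl on the carbonyl carbon would behave like cyclohex-1-en-1-yl or like 4-methylphenyl. Going by these compounds, it also remains open whether a step of this size would recur on the differently substituted cores of compound 2 and compound 3.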